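Methoxy for methyl on the pendant aryl of compound 2

The source may hold more compounds than are shown below. What is called first, only, known or untested is meant among the compounds shown, and "the series" means these compounds.

In a functional assay on MCF7 cells (Homo sapiens) for antiproliferative activity, read by MTT assay, with a stated time of 48 h, in the presence of a further agent that is not named here (on this read-out higher numbers stand for weaker inhibition of growth and lower numbers for stronger inhibition of growth), compound 1 `O=C(NOCc1ccccc1)c1cn(-c2ccccc2)nc1-c1ccccc1` gives 13400 nM, and compound 2 `Cc1ccc(-c2nn(-c3ccccc3)cc2C(=O)NOCc2ccccc2)cc1` gives 1870 nM, the lowest of the two numbers; the step of a 7.2-fold lower number from compound 1 to compound 2 (0.86 log units; beyond the scatter) is the only measured one in the series. Compound 3 `COc1ccc(-c2nn(-c3ccccc3)cc2C(=O)NOCc2ccccc2)cc1` carries the change (methoxy in place of methyl on an aromatic carbon), para to a large group. Among the compounds with values here, no measured step bears directly on this exchange; the step from compound 1 to compound 2 shows only that a small group at this carbon is accepted. A step of no more than the scatter is therefore expected, a 1.2-fold lower number from compound 2 to compound 3 (0.07 log units; within the scatter). For compound 3 the estimate in this assay is 1600 nM, with a range from 500 nM to 5000 nM.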

Compound 3, concentration for 50% growth inhibition: 2770 nM
Compound 3: middle estimate off by 1.7-fold (0.24 log units), on the low side; measured number inside the range.
By their numbers in this assay, from the lowest: compounds 2 and 3 (each within the scatter of the next); then compound 1.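

With a 1.5-fold higher number from compound 2 to compound 3 (0.17 log units; within the scatter), methyl and methoxy are not told apart at this carbon, para to a large group. With a 4.8-fold lower number from compound 1 to compound 3 (0.68 log units; beyond the scatter), the advantage over hydrogen seen with methyl also holds for methoxy, so it does not depend on methyl alone. No measurement available here bears on the reason for either step.

Still open, going by these compounds, is how this carbon responds to an amine, a carboxylic acid or a longer alkoxy chain. The compounds shown also leave open whether methoxy and methyl remain indistinguishable when the rest of the structure is changed.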